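This account rests on a few compounds, and the source may have more. Where it says the series, first, only, none or still open, it means among the compounds named here.

Compound 1 `O=S(=O)(Nc1ccc(-c2nc3ccccc3o2)cc1)c1ccccc1O` stands at a limit of an assay on cells for inhibition of HSP60/HSP10 (Homo sapiens), with a stated time of 60 min; on this read-out higher numbers stand for weaker inhibition and lower numbers for stronger inhibition: in this assay compound 1 gives > 100000 nM, which is a limit rather than a number, so only a range is known for it, as shown by the limit of > 100000 nM in this assay, at which 1 of the 3 values shown sits. Compound 2 `O=S(=O)(Nc1ccc(-c2nc3cc(NS(=O)(=O)c4ccccc4O)ccc3o2)cc1)c1ccccc1O` gives 18000 nM in this assay, and the step of an at least 5.5-fold lower number from compound 1 to compound 2 (0.74 log units; beyond the scatter) carries ((2-hydroxyphenyl)sulfonyl)amino in place of hydrogen on an aromatic carbon. Compound 3 `O=S(=O)(Nc1ccc2oc(-c3ccccc3)nc2c1)c1cccs1` gives 90000 nM in this assay. Compound 4 `O=S(=O)(Nc1ccc(-c2nc3ccccc3o2)cc1)c1ccc(F)cc1` differs from compound 1 by 4-fluorophenyl in place of 2-hydroxyphenyl on a sulfonyl sulfur. Among the compounds with values here, no measured step touches this position; the one recorded step concerns another place, and compound 3 carries a different sulfonyl group on a different arrangement of the shared core. The expected step that the limit leaves unreadable from compound 1 to compound 4 is therefore none beyond the scatter. Compound 4 is expected to give 120000 nM in this assay, between 30000 nM and 500000 nM.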

Compound 4, half-maximal inhibitory concentration: 73000 nM
For compound 4 the middle estimate is 1.6-fold (0.22 log units) above the measured one; the measured number falls inside the stated range.
By their numbers in this assay, from the lowest: compound 2; then compounds 4 and 3 (each within the scatter of the next). At a limit, above all of these: compound 1.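

Within the data shown here, at this position on a sulfonyl sulfur, 4-fluorophenyl in place of 2-hydroxyphenyl gives an at least 1.3-fold lower number from compound 1 to compound 4 (0.13 log units; that floor lies within the scatter), the first reading of this change in this assay. The value for compound 1 is a limit, so the true size of the step cannot be read: the limit of > 100000 nM in this assay, at which 1 of the 4 values shown sits. Compound 4 thus shows only that the hydroxyl of 2-hydroxyphenyl is not required for a measurable number here. Going by these compounds, it remains open whether an amine or a carboxylic acid in place of the fluorine would give a step beyond the scatter, and whether 4-fluorophenyl would behave the same way alongside the ((2-hydroxyphenyl)sulfonyl)amino group of compound 2.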